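The source may hold more compounds than are shown below. What is called first, only, known or untested is meant among the compounds shown, and "the series" means these compounds.

In an ADME assay (liver, Mus musculus) for metabolic stability, using microsomes (on this read-out higher numbers stand for a longer-lived compound and lower numbers for a shorter-lived compound), compound 1 `C=CC(=O)Nc1cccc(CNc2nc(Nc3cnn(C4CCOCC4)c3)ncc2Cl)c1` gives 0.025 h, compound 2 `C=CC(=O)Nc1cccc(CNc2nc(Nc3cnn(C4CCN(C(C)=O)CC4)c3)ncc2Cl)c1` gives 0.05 h and compound 3 `C=CC(=O)Nc1cccc(CNc2nc(Nc3cnn(CCN(C)C)c3)ncc2Cl)c1` gives 0.03 h. Compound 3 therefore stands with the other two, with no separation from either of them beyond the scatter.

The next structure is compound 4 `C=CC(=O)Nc1cccc(CNc2nc(Nc3cnn(CCOC(F)F)c3)ncc2Cl)c1`. The change is difluoromethoxy in place of dimethylamino on a saturated chain carbon, two bonds along the chain from an aromatic nitrogen. For the measured compounds named here, no measured pair makes this exact exchange, so the evidence is indirect.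

Going by the values given here, the steps that bear on it are the three exchanges of the whole group on the aromatic nitrogen: a 1.2-fold higher number from compound 1 to compound 3 (0.08 log units; within the scatter), a 1.7-fold lower number from compound 2 to compound 3 (0.22 log units; within the scatter) and a 2.0-fold higher number from compound 1 to compound 2 (0.30 log units; within the scatter). All three stay within the scatter, although the groups exchanged differ considerably. Three compounds are a thin basis, but they give no reason to expect a step beyond the scatter at this position, and no direction is supported by the data.

The expected change is small, and the estimate is a 1.2-fold higher number from compound 3 to compound 4 (0.07 log units; within the scatter). For compound 4 the expected half-life is 0.035 h, with an estimated range from 0.015 h to 0.08 h.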

Compound 4, half-life: 0.0433 h
For compound 4 the middle estimate is 1.2-fold (0.09 log units) below the measured one, and the stated range covers the measured number.
By their numbers in this assay, from the lowest: compounds 1, 3, 4 and 2 (each within the scatter of the next).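

Unlike the earlier steps, which exchange the whole group on the aromatic nitrogen, this change keeps the ethyl chain and alters only its end, and in this assay it stays within the scatter (a 1.4-fold higher number from compound 3 to compound 4 (0.16 log units; within the scatter)). The 2-(difluoromethoxy)ethyl group also shows no separation from the two groups it can be set against directly, 1-acetylpiperidin-4-yl (a 1.2-fold lower number from compound 2 to compound 4 (0.06 log units; within the scatter)) and oxan-4-yl (a 1.7-fold higher number from compound 1 to compound 4 (0.24 log units; within the scatter)), so all four groups at this position now sit within the scatter of one another. Nothing available explains these numbers or links them to any property of the groups.

From the compounds shown here alone, whether any group at this position can produce a step beyond the scatter remains open, for example a carboxylic acid or a morpholine ring at the end of the ethyl chain, or a longer chain carrying difluoromethoxy. The compounds shown also share the rest of their structure, so they cannot tell whether a change elsewhere on the shared core, such as at the chlorine, would shift the half-life further.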